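Carbonyl aryl swap: pyridin-2-yl to phenyl

The compounds below may be only part of what the source reports. "The series", "measured", "known", "first", "only" and "open" are said of these compounds alone.

Three compounds of the series have numbers in a functional assay on HCT-116 cells (Homo sapiens) for inhibition, read by sulforhodamine B assay, with a stated time of 72 h; a higher number here means a weaker inhibitor, a lower number a stronger inhibitor. Compound 1 `COc1cc(OC)c(C(=O)/C=C/c2cn(-c3ccccc3)nc2-c2ccsc2)c(OC)c1` gives 5200 nM, compound 2 `O=C(/C=C/c1cn(-c2ccccc2)nc1-c1cccnc1)c1ccsc1` gives 1300 nM, and compound 3 `O=C(/C=C/c1cn(-c2ccccc2)nc1-c1cccnc1)c1ccccn1` gives 2100 nM. Compound 3 thus stands second highest of the three, with compound 2 nearest, within the scatter, and compound 1 furthest, beyond it. Going by the values given here, the only measured step at the carbonyl carbon is a 1.6-fold higher number from compound 2 to compound 3 (0.21 log units; within the scatter). Compound 4 `O=C(/C=C/c1cn(-c2ccccc2)nc1-c1cccnc1)c1ccccc1` carries the change (phenyl in place of pyridin-2-yl on a carbonyl carbon), an aryl swap at that same place. Given that a 1.6-fold higher number from compound 2 to compound 3 (0.21 log units; within the scatter) lies within the scatter, the step expected in this assay is a 1.1-fold lower number from compound 3 to compound 4 (0.02 log units; within the scatter), that is, none beyond the scatter. Compound 4 is therefore estimated at 2000 nM, with a range of 800 nM to 5000 nM.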

Compound 4, half-maximal inhibitory concentration: 2000 nM
The estimate for compound 4 equals the measured number at the digits printed; the measured number falls inside the stated range.
By their numbers in this assay, from the lowest: compounds 2, 4 and 3 (each within the scatter of the next); then compound 1.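

At the carbonyl carbon, this assay shows a 1.1-fold lower number from compound 3 to compound 4 (0.02 log units; within the scatter) and a 1.5-fold higher number from compound 2 to compound 4 (0.19 log units; within the scatter) for phenyl, so this ring of carbon only stands within the scatter of both pyridin-2-yl and thiophen-3-yl. The hydrogen-bond acceptor counted for pyridin-2-yl and absent from phenyl thus goes with no step beyond the scatter in this pair.

From the compounds shown here alone, whether an aromatic ring is needed on this carbon stays open, as does the response to an amine or a carboxylic acid on the benzoyl ring. No supporting data explain this result.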